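This account rests on a few compounds, and the source may have more. Where it says the series, first, only, none or still open, it means among the compounds named here.

Measured compounds in a functional assay on HeLa S3 cells (Homo sapiens) for antiproliferative activity, read by XTT assay, with a stated time of 72 h; on this read-out lower numbers stand for stronger inhibition and higher numbers for weaker inhibition:
- Compound 1 `C#Cc1cn([C@@H]2O[C@H](CO)[C@@H](O)[C@H]2O)c2ncnc(NC)c12`: compound 1 gives > 20000 nM; this is a limit of the assay.
- Compound 2 `CNc1ncnc2c1c(-c1ccccc1)cn2[C@@H]1O[C@H](CO)[C@@H](O)[C@H]1O`: compound 2 gives > 20000 nM; this is a limit.
- Compound 3 `CNc1ncnc2c1c(-c1ccsc1)cn2[C@@H]1O[C@H](CO)[C@@H](O)[C@H]1O`: compound 3 gives > 20000 nM; this is a limit.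

Compound 3 thus stands at the same limit as the other two; no value is resolved for it. The steps among the three are all unreadable: a step that the two limits leave unreadable from compound 1 to compound 2, a step that the two limits leave unreadable from compound 1 to compound 3, a step that the two limits leave unreadable from compound 2 to compound 3. The shared feature is the limit of > 20000 nM in this assay, at which 3 of the 3 values shown sit.

Compound 4 `CSc1ncnc2c1c(-c1ccsc1)cn2[C@@H]1O[C@H](CO)[C@@H](O)[C@H]1O` differs from compound 3 by methylsulfanyl in place of methylamino on an aromatic carbon. For the measured compounds named here, no measured step touches the methylamino position, so nothing shows how this change shifts potency. Given that compound 3 sits at the limit, compound 4 is expected to stay at or near it, an expected step that the limit leaves unreadable from compound 3 to compound 4. Compound 4 is estimated at 25000 nM, range 7000 nM to 90000 nM.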

Compound 4, half-maximal inhibitory concentration: > 20000 nM
Compound 4: only a limit was reported; the forecaster's own chance of this, stated with the estimate: 85%; the middle value does not contradict the limit.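

No new step can be read, since compound 3 and compound 4 both stand at a limit: the limit of > 20000 nM in this assay, at which 4 of the 4 values shown sit. The compounds shown leave open whether methylsulfanyl and methylamino differ at all in this assay, and which change to the shared core would give a resolved value.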